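This account rests on a few compounds, and the source may have more. Where it says the series, first, only, none or still open, it means among the compounds named here.

Measured so far:
compound 1 `CC/C(=C(/c1ccc(/C=C/C(=O)O)cc1)c1cc2cn[nH]c2cn1)c1ccccc1` — 442 nM
compound 2 `CC/C(=C(/c1ccc(/C=C/C(=O)O)cc1)c1ccc2[nH]ncc2c1C)c1ccccc1` — 50 nM
compound 3 `CC/C(=C(/c1ccc(/C=C/C(=O)O)cc1)c1cc(F)c2[nH]ncc2c1)c1ccccc1` — 7.5 nM

In a functional assay on MCF7 cells (Homo sapiens) for cytotoxicity, read by CellTiter-Glo, with a stated time of 5 days (on this read-out higher numbers stand for weaker inhibition and lower numbers for stronger inhibition), compound 3 gives 7.5 nM, the lowest number of the three. Its nearest neighbour is compound 2, a step of a 6.7-fold lower number from compound 2 to compound 3 (0.82 log units; beyond the scatter); the furthest is compound 1, a step of a 59-fold lower number from compound 1 to compound 3 (1.77 log units; beyond the scatter).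

Compound 4 `CC/C(=C(/c1ccc(/C=C/C(=O)O)cc1)c1ccc2[nH]nc(Cl)c2c1)c1ccccc1` is not yet measured. Relative to compound 3 the change is 3-chloro-1H-indazol-5-yl in place of 7-fluoro-1H-indazol-5-yl on a double-bonded chain carbon bound to an aromatic carbon and a double-bonded chain carbon. The step that bears most directly on it is a 6.7-fold lower number from compound 2 to compound 3 (0.82 log units; beyond the scatter), where the group attached at this same position was altered in its substituent; the steps of an 8.8-fold lower number from compound 1 to compound 2 (0.95 log units; beyond the scatter) and a 59-fold lower number from compound 1 to compound 3 (1.77 log units; beyond the scatter) show that this position is sensitive to what is carried there, with every change so far moving the number beyond the scatter. Among the compounds with values here, no measured step exchanges a chloro-bearing form of this group for a fluoro-bearing form, so the direction is not fixed by the data. Given that compound 3 already sits at the low end, a modest rise in the number is the more likely expectation. Compound 4 is therefore expected to give about 20 nM in this assay, within 5 nM to 80 nM, a step of a 2.7-fold higher number from compound 3 to compound 4 (0.43 log units; beyond the scatter) from compound 3.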

Compound 4, half-maximal inhibitory concentration: 284 nM
Beside the measured number, compound 4's estimate is 14-fold (1.15 log units) below it; the measured number lies above the stated range.
By their numbers in this assay, from the lowest: compound 3; then compound 2; then compounds 4 and 1 (each within the scatter of the next).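

Exchanging 7-fluoro-1H-indazol-5-yl for 3-chloro-1H-indazol-5-yl in this assay keeps the heavy-atom, donor and acceptor counts unchanged, yet gives the largest step among the groups with a carbon-only six-membered ring (a 38-fold higher number from compound 3 to compound 4 (1.58 log units; beyond the scatter)), so at this position the identity and placement of the substituent matter even when those counts do not change. The chloro group also falls on the high-number side of the methyl-bearing group (a 5.7-fold higher number from compound 2 to compound 4 (0.75 log units; beyond the scatter)), while its step from the group with a hetero atom in the six-membered ring stays within the scatter (a 1.6-fold lower number from compound 1 to compound 4 (0.19 log units; within the scatter)); compound 4 therefore goes against the pattern suggested by compounds 2 and 3, and a carbon-only six-membered ring does not by itself give a lower number than compound 1. No measurement available here accounts for the size of this change.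

The step from compound 3 to compound 4 changes the halogen and its place together, so the contribution of each remains unresolved. The compounds shown also leave open how the unsubstituted 1H-indazol-5-yl group, or versions carrying an amine or a nitrile, would read in this assay.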